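Lengthening and unsaturating the chain of compound 1

The compounds below may be only part of what the source reports. "The series", "measured", "known", "first", "only" and "open" are said of these compounds alone.

Compound 1 `CCCCCCCCCCCCCCCc1cc(=O)c2c(O)cc(O)c(C)c2o1` gives 6790 nM in a functional assay on MDA-MB-231 cells (Homo sapiens) for antiproliferative activity, read by MTT assay; a higher number here means a weaker inhibitor, a lower number a stronger inhibitor.
Compound 2 `CCCCCCCCCCCCCCCc1cc(=O)c2c(O)c(C)c(O)c(C)c2o1` gives > 87000 nM in this assay.

Compound 1 holds the only number shown in this assay. For compound 2 the result is a limit, not a number (the limit of > 87000 nM in this assay, at which 1 of the 2 values shown sits). Within the data shown here, the one measured step, an at least 12-fold higher number from compound 1 to compound 2 (1.10 log units; beyond the scatter), concerns a methyl entering on an aromatic carbon, not the chain, so it says nothing direct about compound 3 `CC/C=C\C/C=C\C/C=C\CCCCCCCc1cc(=O)c2c(O)cc(O)c(C)c2o1`. Compound 3 differs from compound 1 in a group of 10 heavy atoms (10 carbon; no ring) in place of a group of 8 heavy atoms (8 carbon; no ring), on a saturated chain carbon, seven bonds along the chain from an aromatic carbon. Among the measured compounds shown here, no measured step touches this position, so the account has no ground for a change in either direction beyond the scatter, and a wide range is expected. Compound 3 is therefore expected to give 6800 nM in this assay, between 2300 nM and 20000 nM. The step of a 1.0-fold higher number from compound 1 to compound 3 (0.00 log units; within the scatter) is the expected outcome.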

Compound 3, half-maximal inhibitory concentration: 6790 nM
Compound 3: the middle estimate sits 1.0-fold (0.00 log units) above what was measured; measured number inside the range.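

In this assay, replacing the octyl part of the chain with a longer, unsaturated group gives no change at the digits printed from compound 1 to compound 3 (within the scatter). Among these compounds, this is the first reading at this position, seven bonds along the chain from an aromatic carbon, and it shows that the chain of compound 1 can take this longer, unsaturated end with no change beyond the scatter in this cell assay. Nothing shown accounts for this outcome.

Length and unsaturation enter together in compound 3, so the compounds shown do not separate the two, and a longer saturated chain or an unsaturated chain of the original length would be needed to do so. Also open, from the compounds shown here alone, is how a much shorter chain, or a carboxylic acid or an amine at the chain end, would read at this position.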